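A few compounds are considered here, and "the series" means these few. Any claim that something is new, unique, unknown or untested is made for them only; others in the source may bear on it.

The shared core appears first as compound 1 `CS(=O)(=O)Oc1c(C(=O)NCc2ccc(F)cc2)nc(Br)c2cccnc12`, for which a functional assay on MCF7 cells (Homo sapiens) for cytotoxicity, read by MTT assay, with a stated time of 72 h (on this read-out lower numbers stand for stronger inhibition and higher numbers for weaker inhibition), gave "not determined" (no result reported). Compound 2 `Nc1cccc(Nc2c(C(=O)NCc3ccc(F)cc3)nc(Br)c3cccnc23)c1` carries an aminophenyl group on the ring nitrogen, and in this assay compound 2 gives 8000 nM. Compound 3 `C[C@@H](Nc1c(C(=O)NCc2ccc(F)cc2)nc(Br)c2cccnc12)c1ccccc1` has a (1-phenylethyl)amino group in that place, but for compound 3 this assay likewise gave "not determined" (no result reported), so compound 3 stands without any number of its own, and the only measured point in this series is compound 2.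

Compound 4 `NCCCNc1c(C(=O)NCc2ccc(F)cc2)nc(Br)c2cccnc12` is the next member, and the change from compound 3 to compound 4 is 3-aminopropyl in place of 1-phenylethyl on a nitrogen on an aromatic ring. Going by the values given here, since compound 3 has no value, no measured step can be stated, and the direction of the change from compound 3 to compound 4 cannot be read from the data; what can be said is that the one measured relative, compound 2, sits at a weak level in this assay. On that basis compound 4 is expected to land near 10000 nM, within a range from 2000 nM to 50000 nM, with a real chance that this assay reports only a limit.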

Compound 4, half-maximal inhibitory concentration: 6000 nM
Compound 4: the middle estimate sits 1.7-fold (0.22 log units) above what was measured; low and high end bracket the measured number.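

Compound 4 gives this position its second measured point, and with it the first comparison. In this assay, 3-aminopropyl in place of 3-aminophenyl on a nitrogen on an aromatic ring gives a 1.3-fold lower number from compound 2 to compound 4 (0.12 log units; within the scatter), so on this read-out an open chain with no ring cannot be told apart from the aminophenyl group in this one pair. The step from compound 3 to compound 4 cannot be read, and nothing available explains why the two measured numbers lie so close.

Still open, going by these compounds, is whether the amine at the end of the chain matters at all, which a plain propyl group or a chain ending in a hydroxyl or a carboxylic acid would test. A shorter 2-aminoethyl or a longer 4-aminobutyl chain would show whether chain length moves the number.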